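This account rests on a few compounds, and the source may have more. Where it says the series, first, only, none or still open, it means among the compounds named here.

Three compounds share one core and differ only in what sits on the ring amine nitrogen. Compound 1 `CN1CCc2nc(C#Cc3ccccc3)sc2C1` carries methyl there, and in an assay on HEK293 cells for positive allosteric modulation of metabotropic glutamate receptor 5 (Homo sapiens), read by FLIPR, with a stated time of 1 h (on this read-out higher numbers stand for an effect only at larger amounts of compound and lower numbers for an effect already at smaller amounts), compound 1 gives 34 nM. Compound 2 `CCCCN1CCc2nc(C#Cc3ccccc3)sc2C1` carries butyl, and in this assay compound 2 gives 110 nM, a shift of a 3.2-fold higher number from compound 1 to compound 2 (0.51 log units; beyond the scatter). Compound 3 `O=C(C1CC1)N1CCc2nc(C#Cc3ccccc3)sc2C1` carries cyclopropylcarbonyl instead of an alkyl group. For compound 3 this assay reports only a limit, > 10000 nM, which is the limit of > 10000 nM in this assay, at which 1 of the 3 values shown sits. Compound 3 thus stands at the weak end of the three: the steps of an at least 290-fold higher number from compound 1 to compound 3 (2.46 log units; beyond the scatter) and an at least 90-fold higher number from compound 2 to compound 3 (1.95 log units; beyond the scatter) are both large.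

Compound 4 `CC1CC1C(=O)N1CCc2nc(C#Cc3ccccc3)sc2C1` differs from compound 3 by methyl in place of hydrogen on a saturated ring carbon. For the measured compounds named here, none of the measured steps touches the three-membered ring; all three concern the group on the ring nitrogen, and the two that lead to compound 3 are large losses. Going by the values given here, a methyl on the three-membered ring is a small addition to a group whose presence already sets the number beyond the limit; no measured step supports a return toward the numbers of compound 1 or compound 2. Compound 4 is therefore expected to remain at the limit, an expected step that the limit leaves unreadable from compound 3 to compound 4. The estimate for compound 4 is 20000 nM, within 4000 nM to 100000 nM, most likely reported only as a limit.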

Compound 4, half-maximal effective concentration: 9.4 nM
Estimate against measurement, compound 4: 2100-fold (3.33 log units) above; measured number outside the range, below it.
By their numbers in this assay, from the lowest: compound 4; then compound 1; then compound 2. At a limit, above all of these: compound 3.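

In this assay, a methyl in place of hydrogen on a saturated ring carbon of the three-membered ring produces an at least 1000-fold lower number from compound 3 to compound 4 (3.02 log units; beyond the scatter) and so shows that a cyclopropylcarbonyl-type group on the ring amine nitrogen need not mean a loss; this single carbon decides between the weak end and the low end of the series. The (2-methylcyclopropyl)carbonyl group also does better than either alkyl group on that nitrogen, with a 12-fold lower number from compound 2 to compound 4 (1.07 log units; beyond the scatter) and with a 3.6-fold lower number from compound 1 to compound 4 (0.56 log units; beyond the scatter) in the same assay, so the large losses seen earlier belong to cyclopropylcarbonyl and not to every carbonyl-linked group at this nitrogen. The first of these steps gives only a lower bound for the change, since compound 3 has a limit and not a number: the limit of > 10000 nM in this assay, at which 1 of the 4 values shown sits.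

The compounds shown leave open whether an ethyl group or a fluorine atom on the three-membered ring would act as the methyl does, and whether a cyclobutylcarbonyl group on the ring amine nitrogen would follow compound 3 or compound 4. They also offer no explanation for so large a step from one added carbon.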